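The compounds below may be only part of what the source reports. "The series", "measured", "known", "first", "only" and "open" are said of these compounds alone.

Working notes on the tetrazole-chain series. Two compounds carry measured numbers in an assay on isolated protein for antagonist activity at Bile acid receptor (Homo sapiens), read by HTRF, with a stated time of 30 min; on this read-out higher numbers stand for weaker inhibition and lower numbers for stronger inhibition. Compound 1 `CCc1cc(CC)c(OCc2ccccc2)cc1OCCCCCC(C)(C)c1nnn[nH]1` gives 3500 nM in this assay. Compound 2 `CCC(=O)c1cc(CC)c(OCCCCCC(C)(C)c2nnn[nH]2)cc1O` replaces the benzyloxy group and one ethyl of compound 1 with a propanoyl group and a hydroxyl. In this assay compound 2 gives 8500 nM. Going by the values given here, compound 2 therefore stands at the higher of the two numbers, compound 1 being the nearer and only comparator, with a gap between the two that lies beyond the usual scatter; since the two structures differ in more than one place, no single step is assigned to that pair.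

Compound 3 `CCc1cc(C(=O)C(C)C)c(O)cc1OCCCCCC(C)(C)c1nnn[nH]1` is the next member and is not yet measured. It differs from compound 2 in one place only: methyl in place of hydrogen on a saturated chain carbon bound to a carbonyl carbon and a saturated chain carbon. Among the compounds with values here, no step between measured compounds isolates a change of this kind, so there is no measured precedent for its size or direction. The estimated step is a 1.4-fold lower number from compound 2 to compound 3 (0.15 log units; within the scatter), a small change, if anything toward a lower number and not clearly beyond the scatter. Compound 3 is accordingly estimated at 6000 nM in this assay, with a range from 2500 nM to 15000 nM.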

Compound 3, half-maximal inhibitory concentration: 8600 nM
Compound 3: middle estimate off by 1.4-fold (0.16 log units), on the low side; measured number inside the range.
By their numbers in this assay, from the lowest: compound 1; then compounds 2 and 3 (each within the scatter of the next).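

Going by these compounds alone, the step from propanoyl to isopropylcarbonyl (a 1.0-fold higher number from compound 2 to compound 3 (0.01 log units; within the scatter)) is the first single-place comparison, and it gives this position a measured result that the pair of compound 1 and compound 2 could not give. In this assay, methyl in place of hydrogen on a saturated chain carbon bound to a carbonyl carbon and a saturated chain carbon produces no difference beyond the scatter, so compound 2 and compound 3 cannot be separated on this read-out. This is one change at one position, and it sets no trend for other groups there; no information at hand accounts for the result.

On these data alone, whether this position stays equally flat with a larger or different group remains open, for example a tert-butyl, a cyclopropyl or a longer chain in place of the ethyl of propanoyl, or an amine or a carboxylic acid on that saturated chain carbon. The compounds shown also leave unresolved which of the structural differences separating compound 1 from compound 2 and compound 3 accounts for its lower number, since no single-place step connects compound 1 to either of them.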